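This account rests on a few compounds, and the source may have more. Where it says the series, first, only, none or still open, it means among the compounds named here.

Compound 3 `CCc1ccc(-c2ccnc(C(=O)Nc3ccc(Oc4ccnc5[nH]ccc45)c(F)c3)c2)cc1` is taken as the starting point. Among the compounds with values here, in a functional assay on PC-3 cells (Homo sapiens) for cytotoxicity, read by MTT assay, with a stated time of 72 h (on this read-out lower numbers stand for stronger inhibition and higher numbers for weaker inhibition), compound 3 gives 2960 nM, the second highest of the three numbers known. Compound 2 `Cc1ccc(-c2ccnc(C(=O)Nc3ccc(Oc4ccnc5[nH]ccc45)c(F)c3)c2)cc1` gives 3970 nM, and a 1.3-fold lower number from compound 2 to compound 3 (0.13 log units; within the scatter). Compound 1 `Cc1cccc(-c2ccnc(C(=O)Nc3ccc(Oc4ccnc5[nH]ccc45)c(F)c3)c2)c1` gives 860 nM; a 3.4-fold higher number from compound 1 to compound 3 (0.54 log units; beyond the scatter), and a 4.6-fold higher number from compound 1 to compound 2 (0.66 log units; beyond the scatter). Compound 4 `O=C(Nc1ccc(Oc2ccnc3[nH]ccc23)c(F)c1)c1cc(-c2ccc(F)cc2F)ccn1` carries 2,4-difluorophenyl in place of 4-ethylphenyl on an aromatic carbon. Within the data shown here, no measured step places fluorine on this ring, so the two steps from compound 1 give only a loose guide: a change at this ring can shift the number by a modest amount in either direction. Compound 4 is therefore expected to give 1500 nM, within a range of 400 nM to 6000 nM, which would mean a 2.0-fold lower number from compound 3 to compound 4 (0.30 log units; within the scatter).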

Compound 4, half-maximal inhibitory concentration: > 10000 nM
Compound 4: no number, only a limit; the forecaster's own chance of this, stated with the estimate: 5%; at least 6.6-fold (0.82 log units) between middle value and limit.
By their numbers in this assay, from the lowest: compound 1; then compounds 3 and 2 (each within the scatter of the next). At a limit, above all of these: compound 4.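

In this assay compound 4 reaches no number, only a limit: the limit of > 10000 nM in this assay, at which 1 of the 4 values shown sits.

At this position, opposite the ring nitrogen, the change to 2,4-difluorophenyl gives an at least 3.3-fold higher number from compound 3 to compound 4 (0.52 log units; beyond the scatter), an at least 2.5-fold higher number from compound 2 to compound 4 (0.40 log units; beyond the scatter) and an at least 11-fold higher number from compound 1 to compound 4 (1.06 log units; beyond the scatter). The earlier compounds shown here, all with alkyl-bearing phenyl rings, showed only modest steps, whereas this change shows that a substituent swap on this ring can carry the number out of the measured range.

Going by these compounds, it remains open whether both fluorines are needed for this or one alone would do. Also open, on these data alone, is how a phenyl ring bearing a single fluorine, a methoxy group or an amine would read.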